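Expected Small Step from Compound 3 to Compound 4

The compounds below may be only part of what the source reports. "The series", "measured", "known", "first", "only" and "open" are said of these compounds alone.

In a functional assay on MOLT-4 cells (Homo sapiens) for inhibition, read by MTT assay, with a stated time of 72 h (a lower number here means a stronger inhibitor, a higher number a weaker inhibitor), compound 1 (`COc1cc(NC(C)CCCNC(=O)Nc2cccc(Cl)c2)c2ncccc2c1`) gives 21000 nM, compound 2 (`COc1cc(NC(C)CCCNC(=O)Nc2cccc(O)c2)c2ncccc2c1`) gives 24000 nM and compound 3 (`COc1cc(NC(C)CCCNC(=O)NNC(=O)Nc2cccc(C(F)(F)F)c2)c2ncccc2c1`) gives 36000 nM. These three values lie within the usual scatter of one another, so compound 3 cannot be separated from the other two on these numbers.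

The next compound is compound 4 (`COc1cc(NC(C)CCCNC(=O)NNC(=O)Nc2ccc(O)cc2)c2ncccc2c1`), which carries 4-hydroxyphenyl in place of 3-(trifluoromethyl)phenyl on an amide-type nitrogen. The rest of compound 3 stays unchanged.

Going by the values given here, only one measured step bears on this change. It is a 1.1-fold higher number from compound 1 to compound 2 (0.06 log units; within the scatter), with hydroxy in place of chloro on an aromatic carbon, and it stays within the scatter. That step is only a loose guide, as compound 2 has a different linker from compound 3. Among the compounds with values here, no measured step shows the removal of a trifluoromethyl group, and none shows a change on this longer linker.

No step beyond the scatter is therefore expected in this assay, and no direction can be claimed with confidence. The expected step is a 1.2-fold lower number from compound 3 to compound 4 (0.08 log units; within the scatter). For compound 4 the estimated value is 30000 nM, with an expected range of 13000 nM to 70000 nM.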

Compound 4, half-maximal inhibitory concentration: 104000 nM
Compound 4: middle estimate off by 3.5-fold (0.54 log units), on the low side; the whole stated range lies below it.
By their numbers in this assay, from the lowest: compounds 1, 2 and 3 (each within the scatter of the next); then compound 4.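

In this assay, the aryl group on the amide-type nitrogen of the longer linker proved able to move the number beyond the scatter: 4-hydroxyphenyl in place of 3-(trifluoromethyl)phenyl gives a 2.9-fold higher number from compound 3 to compound 4 (0.46 log units; beyond the scatter) and thus a weaker inhibitor. The earlier hydroxy for chloro step on the shorter linker, a 1.1-fold higher number from compound 1 to compound 2 (0.06 log units; within the scatter), had stayed within the scatter, so the earlier compounds had shown no such sensitivity. Compound 4 also separates from both shorter-linker compounds, with a 4.3-fold higher number from compound 2 to compound 4 (0.64 log units; beyond the scatter) and a 5.0-fold higher number from compound 1 to compound 4 (0.69 log units; beyond the scatter), which makes it the weakest inhibitor of the four, while nothing measured here accounts for the step.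

The change alters both the substituent and its place on the ring, so the compounds shown cannot tell whether losing the trifluoromethyl group, gaining the hydroxy group or moving the substituent carries the step. Also open, from the compounds shown here alone, is how the longer linker would fare with an unsubstituted phenyl, or with an amine or a carboxylic acid on that phenyl.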